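A few compounds are considered here, and "the series" means these few. Any claim that something is new, unique, unknown or untested is made for them only; others in the source may bear on it.

Measured so far:
- compound 1 `CCOc1ccc2nc(Cl)c(/C=N/NC(=O)c3cc4cc([N+](=O)[O-])ccc4oc3=O)cc2c1` gives 15700 nM 
- compound 2 `Cc1noc(NS(=O)(=O)c2ccc(NC(=O)c3cc4ccccc4oc3=O)cc2)c1C` gives 26600 nM 

Both values come from a functional assay on CCRF-CEM cells (Homo sapiens) for antiproliferative activity, read by fluorescence and resazurin assay, with a stated time of 48 h (on this read-out lower numbers stand for stronger inhibition and higher numbers for weaker inhibition), and they lie within the scatter of each other, so compound 1 stands level with compound 2 and the two cannot be ranked.

Compound 3 `CCOc1ccc2nc(Cl)c(/C=N/NC(=O)c3cc4cc(Br)ccc4oc3=O)cc2c1` keeps the core of compound 1 and has bromo in place of nitro on an aromatic carbon, on a six-membered aromatic ring of carbon only, part of a fused or bridged system of two rings. The two measured compounds do not differ in one place, so the data show no size for this change. In this assay no step beyond the scatter is expected, and no direction is favoured. The expected step is a 1.1-fold lower number from compound 1 to compound 3 (0.05 log units; within the scatter) and it is only an estimate. For compound 3 the estimated value is 14000 nM with an expected range from 5000 nM to 35000 nM on this read-out.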

Compound 3, half-maximal inhibitory concentration: 12900 nM
Compound 3: the middle estimate sits 1.1-fold (0.04 log units) above what was measured, and the stated range covers the measured number.
By their numbers in this assay, from the lowest: compounds 3, 1 and 2 (each within the scatter of the next, the first and the last beyond it).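

In this assay the series gains its first comparison of compounds that differ in one place, and it shows a 1.2-fold lower number from compound 1 to compound 3 (0.09 log units; within the scatter) for bromo in place of nitro on an aromatic carbon. Within the data shown here, at this position, on a six-membered aromatic ring of carbon only, a single bromine atom can therefore replace the three heavy atoms and two hydrogen-bond acceptors of nitro with no step that stands clear of the scatter. No measured evidence bears on this result.

Going by these compounds, whether an amine, a carboxylic acid or a methoxy group at this carbon would also leave the number within the scatter remains open. Also open, on these data alone, is whether a longer chain in place of the ethoxy group on the shared core would move the number in either direction.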